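Lengthening the Nitrile Chain of Compound 2

A few compounds are considered here, and "the series" means these few. Any claim that something is new, unique, unknown or untested is made for them only; others in the source may bear on it.

Compound 2 `C=CCc1cc(C(C)=O)c(O)cc1OCCCCC#N` gives 57% in an assay on isolated protein for binding affinity to leukotriene B4 receptor 1 (Homo sapiens), tested at 1 uM (on this read-out lower numbers stand for less inhibition and higher numbers for more inhibition at the one concentration tested (going by the name of the read-out)), and stands highest of the two measured compounds. Compound 1 `CCCc1cc(C(C)=O)c(O)cc1OCCCCC#N` gives 37% in this assay; the step of a number 20 percentage points higher from compound 1 to compound 2 (beyond the scatter) separates them. Compound 3 `C=CCc1cc(C(C)=O)c(O)cc1OCCCCCCCC#N` differs from compound 2 by 3-cyanopropyl in place of cyano on a saturated chain carbon, four bonds along the chain from an oxygen on an aromatic ring. Going by the values given here, no measured step bears on this change, since the one known step concerns a different place on the shared core. The expected step of a number 2 percentage points lower from compound 2 to compound 3 (within the scatter) is therefore none beyond the scatter, and the range is set wide for lack of guidance. Compound 3 is estimated to give 55%, within 30% to 80%, in this assay.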

Compound 3, a percentage reported as inhibition, at one concentration (the size of the read-out at that concentration, not a potency): 52%
Beside the measured number, compound 3's estimate is 3 percentage points above it; low and high end bracket the measured number.
By their numbers in this assay, from the lowest: compound 1; then compounds 3 and 2 (each within the scatter of the next).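

In this assay, 3-cyanopropyl in place of cyano gives a number 5 percentage points lower from compound 2 to compound 3 (within the scatter), so at this place on the chain the two nitrile chain lengths cannot be told apart. Going by these compounds alone, this is the first reading at this position, as the earlier step concerned a different place on the shared core. Nothing at hand bears on this result.

On these data alone, whether a carboxylic acid or an amine in place of the nitrile would give a similar number stays open. So does the outcome for a still longer chain ending in a nitrile.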